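A few compounds are considered here, and "the series" means these few. Any claim that something is new, unique, unknown or untested is made for them only; others in the source may bear on it.

In a functional assay on NCI-H1299 cells (Homo sapiens), read by flow cytometry (on this read-out lower numbers stand for an effect already at smaller amounts and higher numbers for an effect only at larger amounts of compound), compound 1 `N#Cc1ncc2nc1OC/C=C\COc1ccc(Cl)cc1NC(=O)N2` gives > 10000 nM as a limit of the assay and not a number. Compound 2 `N#Cc1ncc2nc1OCC/C=C\COc1ccc(Cl)cc1NC(=O)N2` gives > 10000 nM and this too is only a limit. Both therefore sit at the limit of > 10000 nM in this assay, at which 2 of the 2 values shown sit, and cannot be ranked against each other. Compound 3 `N#Cc1ncc2nc1OCC/C=C\COc1ccc(CCCO)cc1NC(=O)N2` carries 3-hydroxypropyl in place of chloro on an aromatic carbon and otherwise keeps the core of compound 2. Going by the values given here, no measured step shows what such a change does here. A moderate move toward lower concentrations in this assay is expected, with the estimated at least 3.3-fold lower number from compound 2 to compound 3 (0.52 log units; beyond the scatter) as its size. Compound 3 is estimated at 3000 nM with an expected range from 500 nM to 10000 nM on this read-out.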

Compound 3, half-maximal effective concentration: > 10000 nM
Compound 3 ended at the assay's limit; the forecaster's own chance of this, stated with the estimate: 35%; middle value at least 3.3-fold (0.52 log units) from the limit.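

In this assay, no step can be read between compound 2 and compound 3, because both values are limits and not numbers: the limit of > 10000 nM in this assay, at which 3 of the 3 values shown sit. The compounds shown leave open how 3-hydroxypropyl in place of chloro changes the read-out, in size or direction.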